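The source may report more compounds than this note shows. Statements on the series, on what has been measured and on what is new or still open speak of the compounds shown alone.

In a physicochemical assay for lipophilicity (a lower number here means a more polar compound, a higher number a more lipophilic compound), compound 2 `Cc1ccc(NC(=O)[C@H](COC(C)C)Oc2ncnc3c2cnn3-c2ccccc2Cl)nc1` gives 3.9. This is within the scatter of compound 3 `COCC[C@H](Oc1ncnc2c1cnn2-c1ccccc1Cl)C(=O)Nc1ccc(C)cn1` at 3.6, while compound 1 `Cc1cnc(NC(=O)[C@H](COC(C)C)Oc2ncnc3c2cnn3-c2ccccc2Cl)cn1` lies lower at 2.1. Compound 4 `CC(C)OC[C@H](Oc1ncnc2c1cnn2-c1ccccc1Cl)C(=O)Nc1ccccn1` differs from compound 2 by hydrogen in place of methyl on an aromatic carbon, which is hydrogen in place of methyl on an aromatic carbon, turning 5-methylpyridin-2-yl into pyridin-2-yl. Among the compounds with values here, no measured step makes this exact change. The nearest exchanges the ring itself and is large, with a number 1.80 log units higher from compound 1 to compound 2 (beyond the scatter). The other lies in the chain, with a number 0.30 log units lower from compound 2 to compound 3 (within the scatter). A modest fall in this assay is therefore expected, much smaller than the ring exchange. The expected change is a number 0.50 log units lower from compound 2 to compound 4 (beyond the scatter). The estimate for compound 4 is 3.4, with an expected range of 3 to 3.8.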

Compound 4, distribution coefficient: 3.5
The estimate for compound 4 lay 0.10 log units below the measured number; low and high end bracket the measured number.
By their numbers in this assay, from the lowest: compound 1; then compounds 4, 3 and 2 (each within the scatter of the next, the first and the last beyond it).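

In this assay, hydrogen in place of methyl on this aromatic carbon gives a number 0.40 log units lower from compound 2 to compound 4 (beyond the scatter), so this small change alone moves the number beyond the scatter, although the step is modest. The pyridin-2-yl amide remains far from the 5-methylpyrazin-2-yl amide, with a number 1.40 log units higher from compound 1 to compound 4 (beyond the scatter), so much of that gap remains without the methyl. Nothing measured here explains either step. 

From the compounds shown here alone, whether another group on this carbon, such as ethyl, methoxy or an amine, would move the number further remains open. So does whether the methyl step would hold on the chain of compound 3.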